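Removing the acetyl from compound 2

The compounds below may be only part of what the source reports. "The series", "measured", "known", "first", "only" and "open" are said of these compounds alone.

compound 1 `CC(=O)Nc1ccc2oc(-c3cccc(F)c3)cc(=O)c2c1`: 240000 nM
compound 2 `COc1c(-c2cccc(F)c2)oc2ccc(NC(C)=O)cc2c1=O`: 210000 nM

Going by the values given here, in an ADME assay on MT4 cells (Homo sapiens) for cytotoxicity, read by MTT assay, with a stated time of 4 days (on this read-out higher numbers stand for lower toxicity in this test and lower numbers for higher toxicity in this test), compound 2 gives 210000 nM and stands within the scatter of compound 1 at 240000 nM which is the only other number available. The unmeasured compound 3 `COc1c(-c2cccc(F)c2)oc2ccc(N)cc2c1=O` differs from compound 2 by hydrogen in place of acetyl on a nitrogen on an aromatic ring, which reads as acetamido to amino: hydrogen in place of acetyl on a nitrogen on an aromatic ring.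

Among the compounds with values here, only one measured step exists. It is a 1.1-fold lower number from compound 1 to compound 2 (0.06 log units; within the scatter) and comes from methoxy in place of hydrogen on an aromatic carbon. That step leaves the acetamido group untouched and stays within the scatter, which makes it a weak guide here. Within the data shown here, no measured pair shows the loss of the acetyl, and both measured compounds carry the acetamido group. A modest move to a lower number is therefore expected, though with little support, and no step beyond the scatter remains possible. In this assay the expected step is a 2.1-fold lower number from compound 2 to compound 3 (0.32 log units; beyond the scatter) as a tentative estimate. Compound 3 is estimated at 100000 nM with 25000 nM to 260000 nM as the expected range.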

Compound 3, half-maximal cytotoxic concentration: 113000 nM
Beside the measured number, compound 3's estimate is 1.1-fold (0.05 log units) below it; measured number inside the range.
By their numbers in this assay, from the lowest: compounds 3, 2 and 1 (each within the scatter of the next, the first and the last beyond it).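

Acetamido to amino, with hydrogen in place of acetyl on a nitrogen on an aromatic ring, gives a 1.9-fold lower number from compound 2 to compound 3 (0.27 log units; within the scatter) in this assay. Going by these compounds alone, this is the first look at this nitrogen, as the earlier step, a 1.1-fold lower number from compound 1 to compound 2 (0.06 log units; within the scatter), concerned an aromatic carbon and left the acetamido group in place; it shows that the whole acetyl, with its 3 heavy atoms and 1 hydrogen-bond acceptor, can leave while the read-out stays within the scatter of compound 2. The information given here offers no explanation for this result.

From the compounds shown here alone, whether the same change holds on the core of compound 1, which lacks the methoxy, remains open, since the loss of the acetyl is seen here only with the methoxy present. Also open, going by these compounds, is how other groups on this nitrogen, such as a longer acyl chain like butanoyl, a methanesulfonyl group or a chain ending in a carboxylic acid, would stand in this assay against the acetamido and amino compounds.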